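This account rests on a few compounds, and the source may have more. Where it says the series, first, only, none or still open, it means among the compounds named here.

Within the data shown here, compound 2 `CC(C)C(Cc1noc(=O)[nH]1)c1ccc(-c2ccc3cccc(F)c3c2)[nH]c1=O` gives 70 nM in a functional assay on CHO cells for antagonist activity at prostaglandin E2 receptor EP3 subtype (Homo sapiens), read by cAMP accumulation (a lower number here means a stronger inhibitor, a higher number a weaker inhibitor), the higher of the two numbers measured so far; compound 1 `CC(C)C(Nc1nccs1)c1ccc(-c2ccc3cccc(F)c3c2)[nH]c1=O` gives 10 nM. Among the measured compounds shown here, the only measured step is a 7.0-fold higher number from compound 1 to compound 2 (0.85 log units; beyond the scatter), a modest loss. Compound 3 `CC(C)C(c1ncc[nH]1)c1ccc(-c2ccc3cccc(F)c3c2)[nH]c1=O` differs from compound 2 by a group of 5 heavy atoms (3 carbon, 2 nitrogen; one five-membered aromatic ring with 2 hetero atoms) in place of a group of 7 heavy atoms (3 carbon, 2 nitrogen, 2 oxygen; one five-membered aromatic ring with 3 hetero atoms), on a saturated chain carbon bound to an aromatic carbon and a saturated chain carbon. For the measured compounds named here, no measured step covers this exact change. The step from compound 1 to compound 2 bears on it indirectly: there a five-membered aromatic ring with 2 hetero atoms gave way to one with 3 hetero atoms on the same chain carbon, and compound 3 moves back to a ring with 2 hetero atoms, though not the group present in compound 1. Part of that loss is therefore expected to be recovered, with compound 3 sitting between the two measured numbers. Compound 3 is estimated at 25 nM, range 8 nM to 80 nM. The expected step is a 2.8-fold lower number from compound 2 to compound 3 (0.45 log units; beyond the scatter).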

Compound 3, half-maximal inhibitory concentration: 33 nM
Beside the measured number, compound 3's estimate is 1.3-fold (0.12 log units) below it, within the range that was stated.
By their numbers in this assay, from the lowest: compound 1; then compound 3; then compound 2.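

In this assay, 1H-imidazol-2-yl on the saturated chain carbon gives a 2.1-fold lower number from compound 2 to compound 3 (0.33 log units; beyond the scatter), so a five-membered aromatic ring with 2 hetero atoms and no linking atom recovers part of the loss seen in the earlier step. It does not fully match the group in compound 1, as the change to 1H-imidazol-2-yl in place of (1,3-thiazol-2-yl)amino gives a 3.3-fold higher number from compound 1 to compound 3 (0.52 log units; beyond the scatter); the three groups at this position therefore give three separable levels, with compound 1 lowest. No measurement shown explains these differences.

The compounds shown leave open whether the ring or the amino link accounts for the advantage of compound 1, since both differ in compound 3. Direct 1,3-thiazol-2-yl on the same chain carbon and (1H-imidazol-2-yl)amino there would separate the two.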